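The compounds below may be only part of what the source reports. "The series", "measured", "known", "first", "only" and "open" are said of these compounds alone.

Measured compounds:
Compound 1 `CC(C)(CC(=O)Nc1ccc(F)c(C(F)(F)F)c1)C(=O)O` gives < 7 uL/min in an ADME assay on microsomes from liver (Homo sapiens) for metabolic stability, using NADPH, with a stated time of 60 min (a lower number here means slower removal, a higher number faster removal of the compound), which is a limit of the assay, not a number.
Compound 2 `O=C(O)CNC(=O)Nc1ccc(F)c(C(F)(F)F)c1` gives < 7 uL/min in this assay, again a limit rather than a number.

Compound 2 therefore stands at the reporting floor of this assay. Going by the values given here, the only measured step, a step that the two limits leave unreadable from compound 1 to compound 2, cannot be read because the limit of < 7 uL/min in this assay, at which 2 of the 2 values shown sit, places both values at that limit. Compound 3 `O=C(Nc1ccc(F)c(C(F)(F)F)c1)NC1(C(=O)O)CCC1` differs from compound 2 by 1-carboxycyclobutyl in place of carboxymethyl on an amide-type nitrogen. Among the compounds with values here, no measured step bears on this change, so nothing beyond the scatter is expected; compound 3 is expected to remain at the limit, with a step that the limit leaves unreadable from compound 2 to compound 3 as the estimated step. Compound 3 is estimated at 4 uL/min, range 1.5 uL/min to 9 uL/min.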

Compound 3, intrinsic clearance in a liver preparation (reported as CLH), per the amount of preparation that the assay uses: 7 uL/min
Estimate against measurement, compound 3: 1.8-fold (0.24 log units) below; low and high end bracket the measured number.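

With 1-carboxycyclobutyl in place of carboxymethyl on an amide-type nitrogen, this assay gives the series its first actual number: compound 3 gives 7 uL/min. Compound 2 gives < 7 uL/min, which is a limit of the assay and not a number. The size of a number no lower from compound 2 to compound 3 (the limit leaves the size open) cannot be read because of this limit: the limit of < 7 uL/min in this assay, at which 2 of the 3 values shown sit.

On these data alone, how a 1-carboxycyclopentyl group, or an amine in place of the carboxylic acid, would read on this nitrogen remains open. Only values clear of the limit would give steps of readable size.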